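Swapping isopropyl for 2,2,2-trifluoroethyl in compound 1

The source may report more compounds than this note shows. Statements on the series, on what has been measured and on what is new or still open speak of the compounds shown alone.

Compound 1 `Cc1csc2cc([C@H](C)Nc3ncnc(N)c3C#N)c(-c3cccc(CN4CCC(N(C)CC(C)C)CC4)c3)c(=O)n12` gives 9.9 h
Compound 2 `Cc1csc2cc([C@H](C)Nc3ncnc(N)c3C#N)c(-c3cccc(CN(C)CCCN(C)Cc4ccc(Cl)cc4)c3)c(=O)n12` gives 13 h
Compound 3 `Cc1csc2cc([C@H](C)Nc3ncnc(N)c3C#N)c(-c3ccccc3)c(=O)n12` gives < 0.1 h

In an ADME assay on the whole organism (lung, Rattus norvegicus) for metabolic stability, read by LC-MS (on this read-out higher numbers stand for a longer-lived compound and lower numbers for a shorter-lived compound), compound 1 gives 9.9 h and compound 2 gives 13 h, two values within the usual scatter of each other. Compound 3 reports only a limit, < 0.1 h, and not a number.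

Compound 4 `Cc1csc2cc([C@H](C)Nc3ncnc(N)c3C#N)c(-c3cccc(CN4CCC(N(C)CCC(F)(F)F)CC4)c3)c(=O)n12` has not been measured yet. It differs from compound 1 by one change: 2,2,2-trifluoroethyl in place of isopropyl on a saturated chain carbon bound to an amine nitrogen. Within the data shown here, no measured pair tests this swap, so no step beyond the scatter is expected, and the estimated change a 1.2-fold lower number from compound 1 to compound 4 (0.09 log units; within the scatter) stays small. For compound 4 the estimated half-life is 8 h (expected range 3 h to 18 h).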

Compound 4, half-life: 8.7 h
Estimate against measurement, compound 4: 1.1-fold (0.04 log units) below; the range from low to high includes it.
By their numbers in this assay, from the lowest: compounds 4, 1 and 2 (each within the scatter of the next). At a limit, below all of these: compound 3.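

In this assay, 2,2,2-trifluoroethyl in place of isopropyl on a saturated chain carbon bound to an amine nitrogen gives a 1.1-fold lower number from compound 1 to compound 4 (0.06 log units; within the scatter) as its step. This is the first comparison shown that changes this one place alone, and the two half-lives cannot be told apart. Nothing measured here gives a reason for this result.

Both groups tested at this place carry no hydrogen-bond donors or acceptors and no net charge. A carboxylic acid, a primary amine or a longer chain there remains an open case.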